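Shortening the Linker Chain: From Compound 3 to Compound 4

The source may report more compounds than this note shows. Statements on the series, on what has been measured and on what is new or still open speak of the compounds shown alone.

Measured compounds:
compound 1, `CC(C)CCc1c(OCCCCCC(=O)NO)ccc(CCC(=O)NO)c1O`, 5410 nM
compound 2, `CC(C)CCc1c(OCCCCCCCC(=O)NO)ccc2c1OC(=O)CC2`, > 30000 nM
compound 3, `CC(C)CCc1c(OCCCCCCCC(=O)NO)ccc2ccc(=O)oc12`, 2190 nM

Of the compounds shown here, three have been tested in a functional assay on A549 cells (Homo sapiens) for antiproliferative activity, read by sulforhodamine B assay, with a stated time of 48 h; a lower number here means a stronger inhibitor of growth, a higher number a weaker inhibitor of growth. Compound 1 gives 5410 nM. For compound 2 the assay reports only a limit, > 30000 nM, and no number. Compound 3 gives 2190 nM, the lowest of the two numbers that were obtained; its nearest neighbour is compound 1, whose number is higher by a gap that lies beyond the usual scatter of repeated measurements.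

Compound 4, `CC(C)CCc1c(OCCCCCC(=O)NO)ccc2ccc(=O)oc12`, has not yet been measured. It differs from compound 3 in one place: hydroxycarbamoyl in place of 2-(hydroxycarbamoyl)ethyl on a saturated chain carbon, five bonds along the chain from an oxygen on an aromatic ring. The chain that carries the hydroxamic acid is thus shorter in compound 4 than in compound 3.

Within the data shown here, no two measured compounds differ in a single place, so nothing among the numbers above fixes the size of this kind of step. The account therefore expects only a modest change, if any, in this assay , most likely a small move toward a weaker inhibitor of growth for compound 4 rather than a large one, so that the expected step is a 1.6-fold higher number from compound 3 to compound 4 (0.20 log units; within the scatter). On that basis compound 4 is estimated at 3500 nM, with a plausible range from 1200 nM to 12000 nM.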

Compound 4, concentration for 50% growth inhibition: 870 nM
Estimate against measurement, compound 4: 4.0-fold (0.60 log units) above, outside the stated range (below it).
By their numbers in this assay, from the lowest: compound 4; then compound 3; then compound 1. At a limit, above all of these: compound 2.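

Among these compounds, exchanging 2-(hydroxycarbamoyl)ethyl for hydroxycarbamoyl on this saturated chain carbon gives, in this assay, a 2.5-fold lower number from compound 3 to compound 4 (0.40 log units; beyond the scatter) and this is the first comparison here in which two compounds differ in one place alone. It shows that, with the rest of compound 3 unchanged, the shorter chain carrying the hydroxamic acid moves the number toward a stronger inhibitor of growth, by a step that lies beyond the usual scatter. Among the compounds shown here, this position therefore responds to the length of the chain, something the earlier compounds could not show, since each of them differs from the others in more than one place.

Going by these compounds, whether a still shorter chain, a longer chain or a carboxylic acid in place of the hydroxamic acid would extend this trend stays open, as does whether the same shortening would have a like effect on the core of compound 1 or of compound 2, the latter known only through a limit. Nothing shown here accounts for the size or the direction of the step.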